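This account rests on a few compounds, and the source may have more. Where it says the series, first, only, none or still open, it means among the compounds named here.

Working notes on the series. The core of compound 1 `CCc1c(SC)nc2nc(C(=O)c3ccccc3)cn2c1C` gives 2 mg/kg in a functional assay on the whole organism with Rattus norvegicus as the target; a lower number here means that less compound is needed, a higher number that more compound is needed for the effect. Compound 2 `CCc1c(OC)nc2nc(C(=O)c3ccccc3)cn2c1C` gives 2 mg/kg, and compound 3 `CCc1c(OC)nc2nc(C(=O)c3ccccc3)cn2c1CC` gives 2 mg/kg; compound 2 is level with both. The two measured steps, no change at the digits printed from compound 1 to compound 2 (within the scatter) and no change at the digits printed from compound 2 to compound 3 (within the scatter), each stay within the scatter, so the series has so far tolerated both changes without a shift in minimum effective dose.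

Compound 4 `COc1cc(C)n2cc(C(=O)c3ccccc3)nc2n1` is next, differing from compound 2 as follows: hydrogen in place of ethyl on an aromatic carbon. Neither measured step removes a chain in this way, so the bearing is indirect; both only show that small changes here have left the read-out flat. Compound 4 is therefore expected at 2 mg/kg, within 1 mg/kg to 6 mg/kg, which would mean an expected step of no change at the digits printed from compound 2 to compound 4 (within the scatter).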

Compound 4, minimum effective dose: 5 mg/kg
Compound 4: middle estimate off by 2.5-fold (0.40 log units), on the low side; measured number inside the range.
By their numbers in this assay, from the lowest: compounds 1, 2 and 3 (each within the scatter of the next); then compound 4.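

Taking the ethyl group off this aromatic carbon, ortho to a methoxy group and ortho to a methyl group, gives the first step beyond the scatter in the series: a 2.5-fold higher number from compound 2 to compound 4 (0.40 log units; beyond the scatter) in this assay. Among the compounds shown here, the shift is modest, but it shows that this position does not share the flatness of the earlier steps, and that hydrogen here needs more compound than ethyl. Nothing shown accounts for the shift.

From the compounds shown here alone, whether methyl or a longer chain such as propyl on this carbon would stay level with ethyl remains open. So does whether an amine here would be tolerated.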